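This account rests on a few compounds, and the source may have more. Where it says the series, first, only, none or still open, it means among the compounds named here.

Measured compounds:
- compound 1, `Cc1ccc(/C=C2\CCC/C(=C\c3cccc([N+](=O)[O-])c3)C2=O)cc1`, 10100 nM
- compound 2, `O=C1CCCC/C1=C\c1ccc([N+](=O)[O-])cc1`, 19300 nM
- compound 3, `COc1cc(/C=C2\CCC/C(=C\c3cccc([N+](=O)[O-])c3)C2=O)cc(OC)c1OC`, 45200 nM

These three compounds were tested in a functional assay on CCRF-CEM cells (Homo sapiens) for cytotoxicity, with a stated time of 72 h; a lower number here means a stronger inhibitor, a higher number a weaker inhibitor. Compound 1 gives the lowest of the three numbers in this assay. The nearest value is that of compound 2, which lies within the scatter of compound 1, so the two cannot be ordered against each other. Compound 3 stands furthest away; its value lies beyond the scatter of compound 1, so compound 1 is the stronger of that pair. No pair among these three differs in a single place, so no individual step can be read from them.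

The unmeasured compound 4, `CN(C)c1ccc(/C=C2\CCC/C(=C\c3cccc([N+](=O)[O-])c3)C2=O)cc1`, shares its core with compound 1. The difference between the two is: dimethylamino in place of methyl on an aromatic carbon.

Among the compounds with values here, no step between measured compounds bears on this change. The expectation rests on compound 1 alone, whose value is 10100 nM. The step of a 1.2-fold lower number from compound 1 to compound 4 (0.07 log units; within the scatter) is expected to be small, with no direction beyond the scatter. Compound 4 is therefore estimated at 8500 nM in this assay, with a range from 3000 nM to 25000 nM.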

Compound 4, half-maximal inhibitory concentration: 11700 nM
Estimate against measurement, compound 4: 1.4-fold (0.14 log units) below, within the range that was stated.
By their numbers in this assay, from the lowest: compounds 1, 4 and 2 (each within the scatter of the next); then compound 3.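

In this assay, within the data shown here, exchanging methyl for dimethylamino on the aromatic carbon gives a 1.2-fold higher number from compound 1 to compound 4 (0.06 log units; within the scatter), the first step that can be read at a single place. At this position, on a six-membered aromatic ring of carbon only and para to a large group, the larger dimethylamino brings in a nitrogen and a hydrogen-bond acceptor that methyl lacks, yet compound 4 and compound 1 stay within the scatter of each other and cannot be ordered. Nothing measured here accounts for this outcome.

What a carboxylic acid, a primary amine or a fluorine would do at this same place remains open, so the compounds shown do not tell whether other groups here would also stay within the scatter of compound 1. Also open, from the compounds shown here alone, is whether the exchange of methyl for dimethylamino would give a similarly small step on a different core, such as that of compound 2.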